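The source may report more compounds than this note shows. Statements on the series, on what has been measured and on what is new or still open speak of the compounds shown alone.

Working notes on the amide series sharing the core of compound 1 `CCCC(=O)Nc1ccc(N2CCN(c3ccc(OC[C@@H]4CO[C@@](Cn5cncn5)(c5ccc(Cl)cc5Cl)O4)cc3)CC2)cc1`.

Within the data shown here, in a functional assay on A549 cells (Homo sapiens) for inhibition, read by MTT assay, with a stated time of 48 h (on this read-out higher numbers stand for weaker inhibition and lower numbers for stronger inhibition), compound 1 gives 2990 nM, the second highest of the three numbers so far. Its nearest neighbour is compound 2 `O=C(CCc1ccccc1)Nc1ccc(N2CCN(c3ccc(OC[C@@H]4CO[C@@](Cn5cncn5)(c5ccc(Cl)cc5Cl)O4)cc3)CC2)cc1`, which gives 2060 nM; the step of a 1.5-fold lower number from compound 1 to compound 2 (0.16 log units; within the scatter) stays within the scatter, so the two are not distinguished. The furthest is compound 3 `O=C(Nc1ccc(N2CCN(c3ccc(OC[C@@H]4CO[C@@](Cn5cncn5)(c5ccc(Cl)cc5Cl)O4)cc3)CC2)cc1)c1ccc(F)c(F)c1`, which gives 8690 nM; the step of a 2.9-fold higher number from compound 1 to compound 3 (0.46 log units; beyond the scatter) is beyond the scatter.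

Compound 4 `O=C(Nc1ccc(N2CCN(c3ccc(OC[C@@H]4CO[C@@](Cn5cncn5)(c5ccc(Cl)cc5Cl)O4)cc3)CC2)cc1)c1cccs1` differs from compound 1 in one place: thiophen-2-yl in place of propyl on a carbonyl carbon. The change sits on the carbonyl carbon whose other neighbour is the amide-type nitrogen, the same place touched in the steps to compound 3. Among the measured compounds shown here, two measured steps bear on it. The step of a 2.9-fold higher number from compound 1 to compound 3 (0.46 log units; beyond the scatter) and the step of a 4.2-fold higher number from compound 2 to compound 3 (0.63 log units; beyond the scatter) both put a 3,4-difluorophenyl on that carbonyl carbon in place of a chain, and both gave modest rises in the number. The thiophen-2-yl likewise brings a five-membered aromatic ring where the propyl chain leaves, so a modest rise is expected, a 1.8-fold higher number from compound 1 to compound 4 (0.26 log units; within the scatter), rather than none. Compound 4 is therefore estimated at 5500 nM, with a range from 2500 nM to 12000 nM.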

Compound 4, half-maximal inhibitory concentration: 4330 nM
The estimate for compound 4 lay 1.3-fold (0.10 log units) above the measured number; measured number inside the range.
By their numbers in this assay, from the lowest: compounds 2, 1, 4 and 3 (each within the scatter of the next, the first and the last beyond it).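

In this assay, the thiophen-2-yl on this carbonyl carbon gives the first aromatic ring here that cannot be told apart from the propyl chain: the step of a 1.4-fold higher number from compound 1 to compound 4 (0.16 log units; within the scatter) stays within the scatter, so an aromatic ring at this place does not always bring a rise that can be read. The same compound also cannot be told apart from the 3,4-difluorophenyl amide, since the step of a 2.0-fold lower number from compound 3 to compound 4 (0.30 log units; within the scatter) is likewise within the scatter, which leaves the rise from compound 1 to compound 3 as the only separation between a chain of this size and a ring placed directly on the carbonyl carbon. Among these compounds, only the step of a 2.1-fold higher number from compound 2 to compound 4 (0.32 log units; beyond the scatter) is beyond the scatter, and it is modest, so the four amides stay within a narrow band, and no measurement at hand speaks to the reason for these differences.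

Still open, going by these compounds, is whether an unsubstituted phenyl or a furan-2-yl on the carbonyl carbon would fall with compound 4 or with compound 3. Also open, on these data alone, is whether an amine or a carboxylic acid at the end of a longer chain would move the number further than any of these four amides.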